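Furan acid series at EP4: replacing the methoxyphenyl arm

The compounds below may be only part of what the source reports. "The series", "measured", "known", "first", "only" and "open" are said of these compounds alone.

Within the data shown here, compound 1 `COc1ccccc1-c1ccc(OCc2cc(C(=O)O)oc2C)cc1` is the weaker of the two compounds measured so far in an assay on cells for displacement of a labelled ligand from prostaglandin E2 receptor EP4 subtype (Homo sapiens), read by scintillation counting; a higher number here means a weaker inhibitor, a lower number a stronger inhibitor; in this assay compound 1 gives 1600 nM. The other measured member, compound 2 `COc1ccc(-c2ccc(OCc3cc(C(=O)NS(=O)(=O)c4c(C)noc4C)oc3C)cc2)c(C)c1`, carries an acylsulfonamide in place of the free acid together with further substitution on the biaryl, and in this assay compound 2 gives 24 nM. Among the measured compounds shown here, no single-point step connects the two, so the difference between them can only be read as the gap between these two numbers.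

Compound 3 `Cc1oc(C(=O)O)cc1COc1ccc(-c2ccncc2)cc1` is not yet measured. It keeps the free acid and the shared core of compound 1 and differs only in the biaryl terminus: pyridin-4-yl in place of 2-methoxyphenyl on an aromatic carbon. With the acid retained and no measured step of this kind in the series, the change is expected to move the inhibition constant little, no further than the scatter in either direction, so the step from compound 1 to compound 3 is estimated at a 1.6-fold higher number from compound 1 to compound 3 (0.19 log units; within the scatter). Compound 3 is therefore expected at about 2500 nM, within a range from 600 nM to 10000 nM.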

Compound 3, inhibition constant: > 10000 nM
Compound 3: no number, only a limit; the forecaster's own chance of this, stated with the estimate: 10%; middle value at least 4.0-fold (0.60 log units) from the limit.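

Compound 3 is recorded only at a limit of the assay, not as a number: the limit of > 10000 nM in this assay, at which 1 of the 3 values shown sits.

In this assay, with the free acid and the shared core kept, pyridin-4-yl in place of 2-methoxyphenyl on an aromatic carbon gives an at least 6.2-fold higher number from compound 1 to compound 3 (0.79 log units; beyond the scatter). Among these compounds, this is the first single-place step, and it shows that binding in this assay responds to the group at this position, which the gap between compound 1 and compound 2 could not show, as those two differ in more than one place. On these data alone, the step has only a lower bound, so its full size remains unknown, and the change removes the methoxy group and brings in the ring nitrogen together.

The compounds shown do not separate these two parts of the change; an unsubstituted phenyl or a pyridin-3-yl at this position would begin to do so. Also open, as far as these compounds go, is whether the same replacement would carry a comparable penalty with the acylsulfonamide of compound 2 in place of the free acid.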